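The source may report more compounds than this note shows. Statements on the series, on what has been measured and on what is new or still open speak of the compounds shown alone.

Compound 2, `CC(C)C1NC(=O)N(C2CCCC2)C1=O`, is one of two measured compounds built on the shared core with a cyclopentyl group. In a functional assay on HeLa cells (Homo sapiens) for inhibition (on this read-out lower numbers stand for stronger inhibition and higher numbers for weaker inhibition), compound 2 gives > 100000 nM, which is a limit of the assay and not a number. Compound 1, `CCC(C)C1NC(=O)N(C2CCCC2)C1=O`, differs from compound 2 by a methyl on a saturated chain carbon. In this assay compound 1 gives > 100000 nM, again a limit rather than a number. The step that the two limits leave unreadable from compound 1 to compound 2 therefore cannot be read, since (the limit of > 100000 nM in this assay, at which 2 of the 2 values shown sit). Compound 3, `O=C1NC(c2ccccc2)C(=O)N1C1CCCC1`, has not yet been measured in this assay. It differs from compound 2 by phenyl in place of isopropyl on a saturated ring carbon. No measured step bears on this change: the only step shown, from compound 1 to compound 2, concerns a methyl on a saturated chain carbon and is itself unreadable. The expected step of a number no higher from compound 2 to compound 3 (the limit leaves the size open) thus rests on nothing more than the position of compound 2 at the limit. Compound 3 is therefore estimated at 100000 nM, in a range from 15000 nM to 500000 nM, with a fair chance that this assay reports only a limit again.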

Compound 3, half-maximal inhibitory concentration: > 100000 nM
Compound 3: only a limit was reported; the forecaster's own chance of this, stated with the estimate: 75%; the middle value lies on the limit itself.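

In this assay compound 3 gives > 100000 nM as a limit of the assay and not a number. For the compounds shown here, no step among compound 1, compound 2 and compound 3 can therefore be read: the limit of > 100000 nM in this assay, at which 3 of the 3 values shown sit. The compounds shown leave open how strongly any of the three inhibits, and whether sec-butyl, isopropyl and phenyl differ at all on this read-out.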